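Replacing Nitro with Cyano in Compound 1

The source may report more compounds than this note shows. Statements on the series, on what has been measured and on what is new or still open speak of the compounds shown alone.

Compound 1 (`C=CCc1ccc(OCc2cn(-c3cccc([N+](=O)[O-])c3)nn2)c(O)c1`) stands highest of the three compounds measured in a functional assay on MCF7 cells (Homo sapiens) for inhibition, read by MTT assay, with a stated time of 72 h, tested at 50 uM (a lower number here means less inhibition of growth, a higher number more inhibition of growth at the concentration tested), where compound 1 gives 56.5%. Compound 3 (`C=CCc1ccc(OCc2cn(-c3ccccc3Cl)nn2)c(O)c1`) gives 34.3%, and compound 2 (`C=CCc1cc(O)c(O)c(CN2CCC(CCO)CC2)c1`) gives 33.3%. Both lie below compound 1 by more than the usual scatter, while the two values sit within the scatter of each other.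

Compound 4 (`C=CCc1ccc(OCc2cn(-c3cccc(C#N)c3)nn2)c(O)c1`) keeps the core of compound 1 and has cyano in place of nitro on an aromatic carbon, (cyano in place of nitro on an aromatic carbon). For the measured compounds named here, no measured pair of compounds isolates this replacement, so the data give no direct guide to its effect. The expectation therefore starts from compound 1 at 56.5% and allows for a wide range. In this assay, a small downward step is expected, one that may not exceed the scatter. The expected change is a number 6.5 percentage points lower from compound 1 to compound 4 (within the scatter). For compound 4 the estimated value is 50%, with an expected range from 33% to 66%.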

Compound 4, percent growth inhibition at one concentration: 33.4%
For compound 4 the middle estimate is 16.6 percentage points above the measured one; measured number inside the range.
By their numbers in this assay, from the lowest: compounds 2, 4 and 3 (each within the scatter of the next); then compound 1.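

In this assay, cyano in place of nitro on an aromatic carbon gives a number 23.1 percentage points lower from compound 1 to compound 4 (beyond the scatter), so this single change separates the two groups at this position by more than the scatter. The step of a number 0.9 percentage points lower from compound 3 to compound 4 (within the scatter), with 3-cyanophenyl in place of 2-chlorophenyl on an aromatic nitrogen, shows that these two groups are not told apart in this assay. Nothing available bears on why nitro and cyano differ at this position.

The compounds shown hold only nitro and cyano at this place, so it remains open whether an amine, a carboxylic acid or a methoxy group there would stand nearer to compound 1 or to compound 4. Nor can they separate the effect of the group from that of its place on the ring, since 3-cyanophenyl and 2-chlorophenyl differ in both.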